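The source may hold more compounds than are shown below. What is called first, only, known or untested is meant among the compounds shown, and "the series" means these compounds.

Values in a functional assay on HeLa cells (Homo sapiens) for inhibition, read by sulforhodamine B assay, with a stated time of 48 h; a higher number here means a weaker inhibitor of growth, a lower number a stronger inhibitor of growth:
- compound 1 `O=C(CCC(F)(F)C(F)(F)C(F)(F)C(F)(F)F)NCCCCCCCCCN[C@@H]1[C@H](O)[C@@H](O)[C@H](O)[C@H]2COC(=O)N21`: > 100000 nM (a limit, not a number)
- compound 2 `O=C(CCC(F)(F)C(F)(F)C(F)(F)C(F)(F)C(F)(F)C(F)(F)F)NCCCCCCCCCN[C@@H]1[C@H](O)[C@@H](O)[C@H](O)[C@H]2COC(=O)N21`: 12000 nM
- compound 3 `O=C(CCC(F)(F)C(F)(F)C(F)(F)C(F)(F)F)NCCCCCCCCCN[C@@H]1[C@H](O)[C@@H](O)[C@@H](O)[C@H]2COC(=O)N21`: 45000 nM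

Compound 3, at 45000 nM, has the higher of the two true numbers in this assay. Compound 4 `O=C(CCC(F)(F)C(F)(F)C(F)(F)C(F)(F)C(F)(F)C(F)(F)F)NCCCCCCCCCN[C@@H]1[C@H](O)[C@@H](O)[C@@H](O)[C@H]2COC(=O)N21` differs from it by 1,1,2,2,2-pentafluoroethyl in place of fluoro on a saturated chain carbon bound to two fluorine atoms and a saturated chain carbon.

The same change gave an at least 8.3-fold lower number from compound 1 to compound 2 (0.92 log units; beyond the scatter). As far as these compounds go, the size of that step stays open because of the limit of > 100000 nM in this assay, at which 1 of the 3 values shown sits. The other measured step, an at least 2.2-fold lower number from compound 1 to compound 3 (0.34 log units; beyond the scatter), is a change of configuration only, and compound 4 keeps the configuration of compound 3. A clear drop of similar size is therefore expected in this assay, resting on this single precedent. The expected step is a 7.5-fold lower number from compound 3 to compound 4 (0.88 log units; beyond the scatter). Compound 4 is estimated at 6000 nM, with an expected range of 1800 nM to 20000 nM.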

Compound 4, concentration for 50% growth inhibition: 10000 nM
Compound 4: middle estimate off by 1.7-fold (0.22 log units), on the low side; the range from low to high includes it.
By their numbers in this assay, from the lowest: compounds 4 and 2 (each within the scatter of the next); then compound 3. At a limit, above all of these: compound 1.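

In this assay, the change from fluoro to 1,1,2,2,2-pentafluoroethyl now has a step of definite size on the core of compound 3 (a 4.5-fold lower number from compound 3 to compound 4 (0.65 log units; beyond the scatter)). With 1,1,2,2,2-pentafluoroethyl in place, the change of configuration at the saturated ring carbon shows nothing beyond the scatter (a 1.2-fold lower number from compound 2 to compound 4 (0.08 log units; within the scatter)).

As far as these compounds go, whether an unfluorinated ethyl group, an amine or a carboxylic acid at this place would give a similar step stays open. Whether the step depends on configuration cannot be read: the same change on two cores in this assay, an at least 8.3-fold lower number (0.92 log units; beyond the scatter) from compound 1 to compound 2 and a 4.5-fold lower number (0.65 log units; beyond the scatter) from compound 3 to compound 4; the limit leaves it open whether they differ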